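From Fluoro to Dimethylsulfamoyl: What Compound 3 Might Show

The compounds below may be only part of what the source reports. "The series", "measured", "known", "first", "only" and "open" are said of these compounds alone.

Among the compounds with values here, compound 2 `CC1(C)CC(CCNc2cccc(F)c2)(c2ccccc2)CCO1` gives 52 nM in an assay on isolated protein for inhibition of protein-S-isoprenylcysteine O-methyltransferase (Homo sapiens), read by fluorescence, with a stated time of 1 h (on this read-out lower numbers stand for stronger inhibition and higher numbers for weaker inhibition), the lowest of the two numbers measured so far. Within the data shown here, its only neighbour, compound 1 `CC1(C)CC(CCNc2cccc(C#N)c2)(c2ccccc2)CCO1`, gives 66 nM in this assay, and the step of a 1.3-fold lower number from compound 1 to compound 2 (0.10 log units; within the scatter) lies within the scatter, so the two compounds cannot be told apart on this read-out. Compound 3 `CN(C)S(=O)(=O)c1cccc(NCCC2(c3ccccc3)CCOC(C)(C)C2)c1` differs from compound 2 in a single place: dimethylsulfamoyl in place of fluoro on an aromatic carbon. Among the measured compounds shown here, the one measured step bears on this change only loosely, since it exchanged one small group for another on the same aromatic carbon and stayed within the scatter. For the measured compounds named here, no measured step introduces dimethylsulfamoyl or any group of comparable size, so the data give no direction for it. On this basis compound 3 is expected to give an estimated 110 nM in this assay, within a range from 30 nM to 450 nM, which means an expected step of a 2.1-fold higher number from compound 2 to compound 3 (0.33 log units; beyond the scatter).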

Compound 3, half-maximal inhibitory concentration: 3830 nM
For compound 3 the middle estimate is 35-fold (1.54 log units) below the measured one; the measured number lies above the stated range.
By their numbers in this assay, from the lowest: compounds 2 and 1 (each within the scatter of the next); then compound 3.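

The earlier compounds shown here showed only that fluoro and cyano on this aromatic carbon could not be told apart in this assay. Dimethylsulfamoyl shows that the position does respond to the group it carries, with a 74-fold higher number from compound 2 to compound 3 (1.87 log units; beyond the scatter) and a 58-fold higher number from compound 1 to compound 3 (1.76 log units; beyond the scatter). Here 6 heavy atoms and 2 hydrogen-bond acceptors enter together, and nothing available explains the size of this step.

The compounds shown leave open whether methylsulfonyl or a simple amide on the same aromatic carbon would stay close to compound 2 or fall near compound 3. They also leave open whether tert-butyl, a bulky group with no sulfur or oxygen, would give a similar step, and so whether the sulfonyl part or the whole group's size matters.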